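A few compounds are considered here, and "the series" means these few. Any claim that something is new, unique, unknown or untested is made for them only; others in the source may bear on it.

Measured compounds in an assay on isolated protein for inhibition of Dihydrofolate reductase (Mus musculus); a lower number here means a less potent compound, a higher number a more potent compound, by a factor of ten per unit of this negative logarithm:

Compound 1, `CC1(C)N=C(N)N=C(N)N1c1cccc(CNC(=O)Nc2cccc(Cl)c2)c1`, gives 8.05.
Compound 2, `CC1(C)N=C(N)N=C(N)N1c1cccc(CNC(=O)Nc2cccc([N+](=O)[O-])c2)c1`, gives 8.1.
Compound 3, `COc1cccc(NC(=O)NCc2cccc(N3C(N)=NC(N)=NC3(C)C)c2)c1`, gives 8.02.

Compound 3 has the lowest of the three numbers in this assay, but only just: the step of a number 0.03 log units lower from compound 1 to compound 3 (within the scatter) and the step of a number 0.08 log units lower from compound 2 to compound 3 (within the scatter) are both within the scatter, as is a number 0.05 log units higher from compound 1 to compound 2 (within the scatter). Across these three compounds the group on the aromatic carbon of the urea-bearing ring makes no difference that can be told from noise.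

Compound 4, `CC1(C)N=C(N)N=C(N)N1c1cccc(CNC(=O)N2CCOCC2)c1`, is the next in line. Its change from compound 3 is morpholin-4-yl in place of (3-methoxyphenyl)amino on a carbonyl carbon. Within the data shown here, no measured step bears on this change: each of the three steps swaps one group for another on the same aromatic carbon, while here the whole (3-methoxyphenyl)amino group, with its aromatic ring and its hydrogen-bond donor, is replaced by morpholin-4-yl. The three steps at hand only show that the series is insensitive to what sits on that aromatic ring; they say nothing about the ring itself being removed. The estimate for compound 4 in this assay is therefore held wide and set somewhat below compound 3, at 7.6 with a range from 6.8 to 8.3. Among the measured compounds shown here, this expected step a number 0.42 log units lower from compound 3 to compound 4 (beyond the scatter) is a guess where no comparable measured step exists.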

Compound 4, logarithm of the reciprocal of the active concentration, log(1/C): 6.43
The estimate for compound 4 lay 1.17 log units above the measured number; the measured number lies below the stated range.
By their numbers in this assay, from the lowest: compound 4; then compounds 3, 1 and 2 (each within the scatter of the next).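

On the carbonyl carbon, replacing the substituted phenylamino group with morpholin-4-yl costs far more in this assay than any change on the aromatic ring did, with the three large steps reading (a number 1.59 log units lower from compound 3 to compound 4 (beyond the scatter)) and (a number 1.67 log units lower from compound 2 to compound 4 (beyond the scatter)) and (a number 1.62 log units lower from compound 1 to compound 4 (beyond the scatter)). The earlier steps shown here showed only that chloro, nitro and methoxy on that ring could not be told apart, whereas this position is clearly sensitive, and the size of the loss holds whichever of the three aryl ureas is taken as the reference. The change removes an aromatic ring of carbon only and a hydrogen-bond donor and brings in a non-aromatic ring with two hetero atoms, and no measurement in hand explains the loss.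

The compounds shown leave open whether the loss follows the aromatic ring, the hydrogen-bond donor or the morpholine ring itself, as all three features change together in this one step. A cyclohexylamino group would keep the donor without the aromatic ring, and a methyl(phenyl)amino group would keep the aromatic ring without the donor, so these two would begin to separate the features.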